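The source may hold more compounds than are shown below. What is called first, only, known or untested is meant among the compounds shown, and "the series" means these compounds.

In a functional assay on SK-BR-3 cells (Homo sapiens) for antiproliferative activity, read by MTT assay, with a stated time of 72 h (a higher number here means a weaker inhibitor, a lower number a stronger inhibitor), three compounds of the shared core have been measured:

Compound 1 `CCN1CCN(c2cc(C)c3cc(NC(=O)c4ccc(Cl)cc4)ccc3n2)CC1`: 3020 nM
Compound 2 `CCN1CCN(c2cc(C)c3cc(NC(=O)c4ccc(F)cc4)ccc3n2)CC1`: 19800 nM
Compound 3 `CCN1CCN(c2cc(C)c3cc(NC(=O)c4ccc(F)c(F)c4)ccc3n2)CC1`: 1980 nM

Compound 3 gives the lowest number of the three. Its gap to compound 1, a 1.5-fold lower number from compound 1 to compound 3 (0.18 log units; within the scatter), is within the scatter, so these two cannot be separated; its gap to compound 2, a 10-fold lower number from compound 2 to compound 3 (1.00 log units; beyond the scatter), lies beyond it. The remaining step, a 6.6-fold higher number from compound 1 to compound 2 (0.82 log units; beyond the scatter), also lies beyond the scatter. Compound 4 `CCN1CCN(c2cc(C)c3cc(NC(=O)c4cc5ccccc5[nH]4)ccc3n2)CC1` has not been measured. It differs from compound 3 in one place: 1H-indol-2-yl in place of 3,4-difluorophenyl on a carbonyl carbon. Within the data shown here, no measured step alters the group on the carbonyl carbon in this way; the steps among compounds 1, 2 and 3 only exchange halogens for hydrogen or for one another on that ring, yet they show that changes to this group can move the number modestly in either direction. Among the measured compounds shown here, with no closer precedent, the expected step of a 1.3-fold higher number from compound 3 to compound 4 (0.10 log units; within the scatter) is kept small and given wide margins. Compound 4 is therefore expected to give about 2500 nM in this assay, within a range of 500 nM to 12000 nM.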

Compound 4, half-maximal inhibitory concentration: 2550 nM
Estimate against measurement, compound 4: 1.0-fold (0.01 log units) below, within the range that was stated.
By their numbers in this assay, from the lowest: compounds 3, 4 and 1 (each within the scatter of the next); then compound 2.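

In this assay, the group on the carbonyl carbon, whose other neighbour is the amide-type nitrogen, need not be a halogen-bearing phenyl ring. The 1H-indol-2-yl group, with its five-membered aromatic ring and its hydrogen-bond donor, cannot be told apart from 3,4-difluorophenyl (a 1.3-fold higher number from compound 3 to compound 4 (0.11 log units; within the scatter)) or from 4-chlorophenyl (a 1.2-fold lower number from compound 1 to compound 4 (0.07 log units; within the scatter)), while it stands clearly apart from 4-fluorophenyl (a 7.8-fold lower number from compound 2 to compound 4 (0.89 log units; beyond the scatter)), so that compound 2 is now the weakest of the four by steps beyond the scatter to each of the others. Nothing available here accounts for why groups so different in shape give numbers this close, or for why 4-fluorophenyl alone stands apart.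

The compounds shown leave open whether the hydrogen on the ring nitrogen of 1H-indol-2-yl matters, a question that 1-methyl-1H-indol-2-yl or benzofuran-2-yl on the same carbonyl carbon would address. They also leave open whether this position needs an aromatic ring at all, as a cyclohexyl group or an aminoalkyl chain in its place would show.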